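Dropping the Methyl from the Ester-Bearing Ring

This account rests on a few compounds, and the source may have more. Where it says the series, first, only, none or still open, it means among the compounds named here.

Of the three measured compounds, compound 2 `COC(=O)c1cccc(C)c1OC(=O)COc1cc(O)c2c(=O)cc(-c3ccccc3)oc2c1` stands at the top of the numbers in a functional assay on cells (T-cell, Mus musculus, strain BALB/c) for inhibition, read by MTT assay, with a stated time of 72 h (a lower number here means a stronger inhibitor, a higher number a weaker inhibitor), giving 39100 nM. Compound 1 `COC(=O)c1ccc(C)cc1OC(=O)COc1cc(O)c2c(=O)cc(-c3ccccc3)oc2c1` gives 31100 nM in this assay, and the change between the two is a 1.3-fold higher number from compound 1 to compound 2 (0.10 log units; within the scatter); the two values are therefore indistinguishable. Compound 3 `COC(=O)c1ccc(Cl)cc1OC(=O)COc1cc(O)c2c(=O)cc(-c3ccccc3)oc2c1` gives 12400 nM in this assay, reached through a 3.2-fold lower number from compound 2 to compound 3 (0.50 log units; beyond the scatter) and through a 2.5-fold lower number from compound 1 to compound 3 (0.40 log units; beyond the scatter).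

Compound 4 `COC(=O)c1ccccc1OC(=O)COc1cc(O)c2c(=O)cc(-c3ccccc3)oc2c1` has not yet been measured in this assay. It differs from compound 2 only at one point: hydrogen in place of methyl on an aromatic carbon.

Within the data shown here, two measured steps bear on this change. The step from compound 1 to compound 2 moves the methyl to a different carbon and produces nothing beyond the scatter, while the step from compound 1 to compound 3 exchanges methyl for chloro and produces a modest gain. Among the measured compounds shown here, neither step removes the methyl altogether, so the closest guide is the first, which suggests the methyl itself carries little weight. Compound 4 is therefore expected to sit close to compound 2, with a step of a 1.2-fold lower number from compound 2 to compound 4 (0.09 log units; within the scatter) that is expected to remain within the scatter. The estimate for compound 4 in this assay is 32000 nM, expected to fall between 13000 nM and 80000 nM.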

Compound 4, half-maximal inhibitory concentration: 28500 nM
The estimate for compound 4 lay 1.1-fold (0.05 log units) above the measured number; the measured number falls inside the stated range.
By their numbers in this assay, from the lowest: compound 3; then compounds 4, 1 and 2 (each within the scatter of the next).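

Taking the methyl away altogether, which the earlier compounds did not do, leaves the number in this assay unmoved, with a 1.4-fold lower number from compound 2 to compound 4 (0.14 log units; within the scatter) and, against the other methyl compound, a 1.1-fold lower number from compound 1 to compound 4 (0.04 log units; within the scatter), so hydrogen and methyl cannot be told apart on this ring in these compounds. The chloro compound alone stands apart, with a 2.3-fold higher number from compound 3 to compound 4 (0.36 log units; beyond the scatter), which shows that the lower number of compound 3 is a gain from chloro over an unsubstituted carbon and not merely a difference from methyl, while compounds 1, 2 and 4 form one group without any order among them. No measurement here speaks to why chloro separates from hydrogen and methyl on this ring.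

The compounds shown leave open whether the gain belongs to chloro alone or would also come with fluoro, bromo, methoxy or an amine on the same carbon, and whether chloro would give the same step on the carbon that carries the methyl in compound 2. They also leave open how much the methoxycarbonyl group contributes, since a carboxylic acid or an amide in its place would test a part of the ring that stays fixed throughout these four compounds.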